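The source may hold more compounds than are shown below. What is called first, only, known or untested is meant among the compounds shown, and "the series" means these compounds.

Within the data shown here, the three compounds measured so far share one core and differ only in the aromatic group attached to it. In a physicochemical assay for solubility, read by LC-MS, in phosphate buffer, with a stated time of 24 h, at pH 7.4 (on this read-out lower numbers stand for lower solubility and higher numbers for higher solubility), compound 1 `Cc1cc(-c2cnc(NCc3c(F)ccc4c3CCO4)c3cn[nH]c(=O)c23)n(C)n1` gives 1000 nM. In this assay compound 2 `Cn1cc(-c2cnc(NCc3c(F)ccc4c3CCO4)c3cn[nH]c(=O)c23)cn1` gives 1000 nM, and no change at the digits printed from compound 1 to compound 2 (within the scatter). Compound 3 `Cc1nn(C)cc1-c1cnc(NCc2c(F)ccc3c2CCO3)c2cn[nH]c(=O)c12` gives 9000 nM in this assay, the highest of the three numbers, set apart from both others beyond the scatter: a 9.0-fold higher number from compound 1 to compound 3 (0.95 log units; beyond the scatter) and a 9.0-fold higher number from compound 2 to compound 3 (0.95 log units; beyond the scatter).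

Compound 4 `Cc1ncccc1-c1cnc(NCc2c(F)ccc3c2CCO3)c2cn[nH]c(=O)c12` differs from compound 3 in one place: 2-methylpyridin-3-yl in place of 1,3-dimethyl-1H-pyrazol-4-yl on an aromatic carbon. The two measured steps that lead to compound 3 change the same aromatic group and were each modest in size, but neither exchanges a pyrazole for a pyridine, so they fix neither the direction nor the size of this new change with confidence. With compound 3 alone at the top and the two other groups tried at this place both giving lower numbers, a modest fall is the more likely outcome. Compound 4 is therefore expected to give 3000 nM in this assay, with a range from 800 nM to 12000 nM. The expected step is a 3.0-fold lower number from compound 3 to compound 4 (0.48 log units; beyond the scatter).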

Compound 4, solubility: < 2000 nM
Compound 4: only a limit was reported; the forecaster's own chance of this, stated with the estimate: 5%; middle value at least 1.5-fold (0.17 log units) away from the limit.
By their numbers in this assay, from the lowest: compounds 1 and 2 (each within the scatter of the next); then compound 3.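

In this assay compound 4 is reported only as a limit, < 2000 nM. Even so, replacing 1,3-dimethyl-1H-pyrazol-4-yl with 2-methylpyridin-3-yl gives an at least 4.5-fold lower number from compound 3 to compound 4 (0.65 log units; beyond the scatter), the first readable step at this position that takes the aromatic group away from a pyrazole. The high number of compound 3 therefore does not carry over to this six-membered aromatic ring with 1 hetero atom, even though the entering group also carries a methyl and has the same count of heavy atoms.

On these data alone, the steps from compound 1 and from compound 2 to compound 4 cannot be read, so the order of these three compounds stays open. Also open, as far as these compounds go, is whether an amine or a carboxylic acid on the 2-methylpyridin-3-yl ring would change the number in this assay.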